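This account rests on a few compounds, and the source may have more. Where it says the series, first, only, none or still open, it means among the compounds named here.

Measured so far:
- compound 1, `NC(=O)N(O)CC1=Cc2cc(OCc3ccccc3)ccc2OC1`: 440 nM
- compound 2, `CCCCNC(=O)N(O)CC1=Cc2cc(Oc3ccccc3)ccc2OC1`: 65 nM

Both compounds share the same core and were tested in an assay (Cavia porcellus) for inhibition of Polyunsaturated fatty acid 5-lipoxygenase (Homo sapiens); on this read-out higher numbers stand for weaker inhibition and lower numbers for stronger inhibition. Compound 1 gives 440 nM, whereas compound 2 gives 65 nM, which is the lowest of the two numbers and a gap beyond the usual scatter. Going by the values given here, no single-change step between these two is available, since they differ in more than one place.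

Compound 3, `CCOC(=O)CNC(=O)N(O)CC1=Cc2cc(Oc3ccccc3)ccc2OC1`, is not yet measured. It differs from compound 2 in one place: ethoxycarbonyl in place of propyl on a saturated chain carbon bound to an amide-type nitrogen. The butyl chain of compound 2 becomes an (ethoxycarbonyl)methyl group. Among the compounds with values here, the data so far give no comparison of this kind, so the expectation rests on the single value of compound 2 alone. A moderate weakening is expected in this assay, a 3.1-fold higher number from compound 2 to compound 3 (0.49 log units; beyond the scatter), with wide uncertainty. Compound 3 is estimated at 200 nM, within a range from 60 nM to 700 nM.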

Compound 3, half-maximal inhibitory concentration: 68 nM
The estimate for compound 3 lay 2.9-fold (0.47 log units) above the measured number; low and high end bracket the measured number.
By their numbers in this assay, from the lowest: compounds 2 and 3 (each within the scatter of the next); then compound 1.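

In this assay, ethoxycarbonyl in place of propyl on a saturated chain carbon bound to an amide-type nitrogen gives a 1.0-fold higher number from compound 2 to compound 3 (0.02 log units; within the scatter), so the two compounds cannot be told apart on this read-out. The entering group carries oxygen atoms and hydrogen-bond acceptors that propyl lacks, so, for this one pair, the number does not depend on the chain being made of carbon alone. Nothing available here explains why the two groups match.

This single pair cannot show how far that freedom extends at this place. A carboxylic acid in place of the ethoxycarbonyl group, an amine at the end of the chain, or a longer chain could each hold the number or move it well beyond the scatter.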